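This account rests on a few compounds, and the source may have more. Where it says the series, first, only, none or still open, it means among the compounds named here.

Three measured compounds frame the comparison. Compound 1 `CCC1(CCCCN2CCN(c3ccc(C)c(Cl)c3)CC2)C(=O)Nc2ccccc21` gives 0.66 nM in an assay on CHO cells for displacement of a labelled ligand from 5-hydroxytryptamine receptor 7 (Homo sapiens) (on this read-out lower numbers stand for stronger inhibition and higher numbers for weaker inhibition), the lowest number of the three. Compound 2 `CCC1(CCCCCN2CCN(c3cccc(Cl)c3)CC2)C(=O)Nc2ccccc21` gives 1.45 nM in this assay, and compound 3 `CCC1(CCCCN2CCc3sccc3C2)C(=O)Nc2ccccc21` gives 4.31 nM; both sit beyond the scatter from compound 1, so compound 1 is the strongest of the set.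

Compound 4 `CCC1(CCCCN2CCN(c3ccccc3Cl)CC2)C(=O)Nc2ccccc21` has not yet been measured. It differs from compound 1 at the amine nitrogen in the ring: 2-chlorophenyl in place of 3-chloro-4-methylphenyl on an amine nitrogen in a ring. Among the measured compounds shown here, no measured pair isolates this change, so its effect is open. The author expects a modest weakening, with a 3.0-fold higher number from compound 1 to compound 4 (0.48 log units; beyond the scatter) from compound 1 to compound 4, not far beyond the scatter. For compound 4 the estimate in this assay is 2 nM, ranging from 0.7 nM to 6 nM.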

Compound 4, inhibition constant: 5.11 nM
The estimate for compound 4 lay 2.6-fold (0.41 log units) below the measured number; low and high end bracket the measured number.
By their numbers in this assay, from the lowest: compound 1; then compound 2; then compounds 3 and 4 (each within the scatter of the next).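

In this assay, among the compounds shown here, putting 2-chlorophenyl in place of 3-chloro-4-methylphenyl on the amine nitrogen in a ring brings a 7.7-fold higher number from compound 1 to compound 4 (0.89 log units; beyond the scatter) and gives the first reading of this position. The number therefore responds to the group on this nitrogen, although this one step changes both the chlorine's place and the presence of the methyl, so neither can be credited alone. Nothing at hand accounts for the change. Still open, as far as these compounds go, is how a 4-methylphenyl or an unsubstituted phenyl would fare on this nitrogen with the same butyl-length chain.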